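Swapping a nitro for a bromo on a hydrazine-bearing core

The source may report more compounds than this note shows. Statements on the series, on what has been measured and on what is new or still open speak of the compounds shown alone.

Three compounds were tested in a functional assay on HepG2 cells (Homo sapiens) for cytotoxicity, read by MTT assay, with a stated time of 72 h; on this read-out higher numbers stand for weaker inhibition and lower numbers for stronger inhibition. Compound 1 `CNC(=O)c1cc(Oc2ccc(C3=NNC(c4cccc(Br)c4)C3)cc2)ccn1` gives 1850 nM. Compound 2 `CNC(=O)c1cc(Oc2ccc(C3=NNC(c4cccc([N+](=O)[O-])c4)C3)cc2)ccn1` gives 26500 nM. Compound 3 `CNC(=O)c1cc(Oc2ccc(C3CC(c4ccc([N+](=O)[O-])cc4)=NN3)cc2)ccn1` gives 28900 nM, a value that lies within the usual scatter of the value of compound 2, so the two cannot be told apart. The difference between the two cores of compound 2 and compound 3 is not broken down here; they contain the same atoms joined differently.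

One change is measured directly. From compound 2 to compound 1 the change is bromo in place of nitro on an aromatic carbon, and it gives a 14-fold lower number from compound 2 to compound 1 (1.16 log units; beyond the scatter).

Compound 4 `CNC(=O)c1cc(Oc2ccc(C3CC(c4ccc(Br)cc4)=NN3)cc2)ccn1` has not yet been measured. It arises from compound 3 by bromo in place of nitro on an aromatic carbon. For the measured compounds named here, this is the same kind of change as the one from compound 2 to compound 1, but not the same: in compound 1 the bromo sits meta to a large group, in compound 4 it sits para to a large group, and the core beneath it differs.

Because the measured step of a 14-fold lower number from compound 2 to compound 1 (1.16 log units; beyond the scatter) is large and well beyond the scatter, a step of similar direction is expected here, and compound 4 is estimated to show a 12-fold lower number from compound 3 to compound 4 (1.06 log units; beyond the scatter). The estimate for compound 4 is 2500 nM, with a range from 900 nM to 9000 nM, kept wide since the change is made on a different core and at a different place on the ring.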

Compound 4, half-maximal inhibitory concentration: 16900 nM
Compound 4: middle estimate off by 6.8-fold (0.83 log units), on the low side; measured number outside the range, above it.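

In this assay the change from 4-nitrophenyl to 4-bromophenyl gives a 1.7-fold lower number from compound 3 to compound 4 (0.23 log units; within the scatter), so compound 3 and compound 4 cannot be told apart on this read-out. The large gain seen on the core of compound 2 therefore does not carry over in size to the core of compound 3, and the two steps are truly different rather than two noisy readings of one effect: the same change on two cores in this assay, a 14-fold lower number (1.16 log units; beyond the scatter) from compound 2 to compound 1 and a 1.7-fold lower number (0.23 log units; within the scatter) from compound 3 to compound 4, 8.4-fold (0.92 log units) apart, beyond the scatter of two such steps. What this does not show is which difference between the two pairs matters, since they differ both in the core and in where the group sits on the ring, and two steps cannot establish a rule for the rest of the series.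

The compounds shown leave open how a bromo behaves on the core of compound 1 when it is para to a large group, a comparison that would help separate the effect of the core from the effect of the place on the ring. They also leave open whether other groups at this place on compound 3 and compound 1, such as a chloro, a methoxy or an amine, would follow the bromo on either core.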